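Efficacy at prostaglandin D2 receptor 2: replacing the aryl group

This account rests on a few compounds, and the source may have more. Where it says the series, first, only, none or still open, it means among the compounds named here.

Compound 1 `N#Cc1ccc(-c2nc(C(c3ccc(F)cc3)c3ccc(F)cc3)sc2CC(=O)O)cc1` gives 30%
Compound 2 `NS(=O)(=O)c1cccc(-c2nc(C(c3ccc(F)cc3)c3ccc(F)cc3)sc2CC(=O)O)c1` gives 55%

For the measured compounds named here, in an in vitro functional assay on HEK285-7 cells for antagonist activity at prostaglandin D2 receptor 2 (Homo sapiens), read by BRET and beta-arrestin recruitment (a higher number here means a larger maximal response, a lower number a smaller maximal response), compound 2 holds the higher of the two values shown, the only measured step being a number 25 percentage points higher from compound 1 to compound 2 (beyond the scatter). Compound 3 `O=C(O)Cc1sc(C(c2ccc(F)cc2)c2ccc(F)cc2)nc1-c1cc(F)nc(F)c1` differs from compound 2 in one place: 2,6-difluoropyridin-4-yl in place of 3-sulfamoylphenyl on an aromatic carbon. Going by the values given here, no measured step covers a 2,6-difluoropyridin-4-yl; the one step known, a number 25 percentage points higher from compound 1 to compound 2 (beyond the scatter), shows only that changing the group at this position can move the response by a modest amount. The step of a number 15 percentage points lower from compound 2 to compound 3 (beyond the scatter) is therefore expected to be small and uncertain in direction. Compound 3 is estimated at 40%, between 15% and 65%.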

Compound 3, largest response reached (reported as efficacy), in percent of the reference or control that the assay uses: 80%
Compound 3: middle estimate off by 40 percentage points, on the low side, outside the stated range (above it).
By their numbers in this assay, from the lowest: compound 1; then compound 2; then compound 3.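

Replacing the aryl group with 2,6-difluoropyridin-4-yl gives a number 25 percentage points higher from compound 2 to compound 3 (beyond the scatter) and a number 50 percentage points higher from compound 1 to compound 3 (beyond the scatter) in this assay and so shows that this position can carry the response much further than the first two compounds suggested. This group has no hydrogen-bond donor, so a donor on this group is not needed for the highest response of the three. Nothing available explains the rise.

On these data alone, it remains open whether the ring nitrogen or the two fluorines matter more. Plain pyridin-4-yl, or an amine in place of one fluorine, would help separate them.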